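The compounds below may be only part of what the source reports. "The series", "measured", "known", "first", "only" and "open" are said of these compounds alone.

Working notes on the series around the shared core, varied only at one arm. Compound 1 `O=C1O[C@H]([C@@H](O)Cn2cc(-c3cccc(O)c3)nn2)C(OCc2ccccc2)=C1OCc1ccccc1` gives in a functional assay on MCF7 cells (Homo sapiens) for antiproliferative activity, read by MTT assay, with a stated time of 72 h (a lower number here means a stronger inhibitor, a higher number a weaker inhibitor), a value of 51800 nM, the highest number among the three measured, though compound 3 sits within the scatter of it. Compound 2 `O=C1O[C@H]([C@@H](O)Cn2cc(CNS(=O)(=O)c3ccc(Cl)cc3)nn2)C(OCc2ccccc2)=C1OCc1ccccc1` gives 4170 nM, and compound 3 `O=C1O[C@H]([C@@H](O)Cn2cc(-c3cc(F)cc(F)c3)nn2)C(OCc2ccccc2)=C1OCc1ccccc1` gives 27700 nM. Compound 4 `O=C1O[C@H]([C@@H](O)Cn2ccnn2)C(OCc2ccccc2)=C1OCc1ccccc1` carries the change (hydrogen in place of 3-hydroxyphenyl on an aromatic carbon). Going by the values given here, no measured step matches it: swapping one aryl group for another, a 1.9-fold lower number from compound 1 to compound 3 (0.27 log units; within the scatter), stays within the scatter, while a 12-fold lower number from compound 1 to compound 2 (1.09 log units; beyond the scatter) shows the arm can carry a large step. With the 3-hydroxyphenyl gone, a small loss is expected, so compound 4 is estimated at a 1.6-fold higher number from compound 1 to compound 4 (0.22 log units; within the scatter). Compound 4 is thus expected near 85000 nM, between 30000 nM and 250000 nM.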

Compound 4, half-maximal inhibitory concentration: > 100000 nM
Compound 4: no number, only a limit; the forecaster's own chance of this, stated with the estimate: 25%; middle value at least 1.1-fold (0.07 log units) from the limit.
By their numbers in this assay, from the lowest: compound 2; then compounds 3 and 1 (each within the scatter of the next). At a limit, above all of these: compound 4.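

Compound 4 has no number in this assay, only a limit: the limit of > 100000 nM in this assay, at which 1 of the 4 values shown sits.

Hydrogen on this aromatic carbon costs clearly more against the other two arms, with an at least 3.6-fold higher number from compound 3 to compound 4 (0.55 log units; beyond the scatter) and an at least 23-fold higher number from compound 2 to compound 4 (1.37 log units; beyond the scatter), whereas an at least 1.9-fold higher number from compound 1 to compound 4 (0.28 log units; that floor lies within the scatter) has a floor that cannot by itself show a loss. Of the compounds shown, the unsubstituted 1H-1,2,3-triazol-1-yl alone gives only a limit, so the arm matters for a measurable number in this assay.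

On these data alone, how far compound 4 really lies beyond its limit remains unknown. Also open, as far as these compounds go, is whether a small group at this carbon, such as methyl or an amine, would keep a measurable number.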